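Fluorine position in the benzyl ether of the aryloxy series

The source may hold more compounds than are shown below. What is called first, only, known or untested is meant among the compounds shown, and "the series" means these compounds.

In an assay on isolated protein (kidney, strain Wistar) for displacement of a labelled ligand from Translocator protein (Rattus norvegicus), read by scintillation counting, with a stated time of 90 min (on this read-out higher numbers stand for weaker inhibition and lower numbers for stronger inhibition), compound 1 `CCN(CC)C(=O)Cc1c(-c2ccc(OC(C)C)cc2)nn2c(C)cc(C)nc12` gives 2.2 nM, compound 2 `CCN(CC)C(=O)Cc1c(-c2ccc(OC3CCC3)cc2)nn2c(C)cc(C)nc12` gives 0.86 nM and compound 3 `CCN(CC)C(=O)Cc1c(-c2ccc(OCc3ccccc3F)cc2)nn2c(C)cc(C)nc12` gives 0.31 nM, the lowest of the three numbers. The steps run a 2.6-fold lower number from compound 1 to compound 2 (0.41 log units; beyond the scatter), a 2.8-fold lower number from compound 2 to compound 3 (0.44 log units; beyond the scatter) and a 7.1-fold lower number from compound 1 to compound 3 (0.85 log units; beyond the scatter). Compound 4 `CCN(CC)C(=O)Cc1c(-c2ccc(OCc3cccc(F)c3)cc2)nn2c(C)cc(C)nc12` differs from compound 3 by 3-fluorophenyl in place of 2-fluorophenyl on a saturated chain carbon bound to an oxygen on an aromatic ring. Among the measured compounds shown here, every measured step exchanges the whole group on the oxygen; none exchanges 2-fluorophenyl for 3-fluorophenyl, so no measured step bears directly on this change. A step inside the usual scatter of this assay is therefore expected, with no direction favoured; the expected step is a 1.3-fold higher number from compound 3 to compound 4 (0.11 log units; within the scatter). Compound 4 is estimated at 0.4 nM, within a range from 0.15 nM to 1.2 nM.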

Compound 4, inhibition constant: 0.47 nM
The estimate for compound 4 lay 1.2-fold (0.07 log units) below the measured number, within the range that was stated.
By their numbers in this assay, from the lowest: compounds 3, 4 and 2 (each within the scatter of the next, the first and the last beyond it); then compound 1.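

In this assay, 3-fluorophenyl in place of 2-fluorophenyl on the saturated chain carbon bound to the oxygen gives a 1.5-fold higher number from compound 3 to compound 4 (0.18 log units; within the scatter), so these two fluorine placements cannot be told apart on this read-out. The 3-fluorobenzyl ether remains clearly separated from isopropyl (a 4.7-fold lower number from compound 1 to compound 4 (0.67 log units; beyond the scatter)), but not from cyclobutyl (a 1.8-fold lower number from compound 2 to compound 4 (0.26 log units; within the scatter)), whereas the 2-fluorobenzyl ether was separated from both. No measurement at hand accounts for this result.

Open, on these data alone, is how plain benzyl, a chlorobenzyl or a pyridylmethyl group on the oxygen would compare with the two fluorobenzyl ethers.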